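The source may hold more compounds than are shown below. What is called first, only, known or untested is meant among the compounds shown, and "the series" means these compounds.

Of the compounds shown here, three built on one shared core have been measured in an ADME assay on microsomes from liver (Mus musculus, strain CD1) for metabolic stability, read by LC-MS, using NADPH, with a stated time of 60 min; a higher number here means that the compound lasts longer, a lower number that the compound disappears faster. Compound 1 `COc1ccc(Cn2c(-c3ccccc3)c(-c3ccccc3)c3c(=N)n([C@H]4CC[C@H](O)CC4)cnc32)cc1` gives 2 h. Compound 2 `COc1ccc(Cn2c(-c3ccccc3)c(-c3ccccc3)c3c(=N)n(CCCO)cnc32)cc1` gives 0.332 h. Compound 3 `COc1ccc(Cn2c(-c3ccccc3)c(-c3ccccc3)c3c(=N)n(CC4CCCO4)cnc32)cc1` gives 0.157 h, the lowest number of the three: the step of a 2.1-fold lower number from compound 2 to compound 3 (0.33 log units; beyond the scatter) and the step of a 13-fold lower number from compound 1 to compound 3 (1.11 log units; beyond the scatter) both lie beyond the scatter.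

Compound 4 `COc1ccc(Cn2c(-c3ccccc3)c(-c3ccccc3)c3c(=N)n(CCO)cnc32)cc1` is not yet measured. It differs from compound 3 in one place: hydroxymethyl in place of oxolan-2-yl on a saturated chain carbon bound to an aromatic nitrogen. The most direct guide is the step of a 2.1-fold lower number from compound 2 to compound 3 (0.33 log units; beyond the scatter), which covers the same swap of a ring for a hydroxyl-bearing chain, only run the other way and with a chain one carbon longer. The steps of a 6.0-fold lower number from compound 1 to compound 2 (0.78 log units; beyond the scatter) and a 13-fold lower number from compound 1 to compound 3 (1.11 log units; beyond the scatter) show that the hydroxyl-bearing chain of compound 2 sits between the two. The expectation for compound 4 in this assay is therefore a modest rise, a 1.9-fold higher number from compound 3 to compound 4 (0.28 log units; within the scatter), near the number of compound 2. The half-life of compound 4 is estimated at 0.3 h, with a likely range from 0.12 h to 0.7 h.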

Compound 4, half-life: 0.518 h
The estimate for compound 4 lay 1.7-fold (0.24 log units) below the measured number; low and high end bracket the measured number.
By their numbers in this assay, from the lowest: compound 3; then compounds 2 and 4 (each within the scatter of the next); then compound 1.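

In this assay, the open 2-hydroxyethyl chain outlasts the (oxolan-2-yl)methyl group (a 3.3-fold higher number from compound 3 to compound 4 (0.52 log units; beyond the scatter)), so the change from the oxolane ring to this chain at the aromatic nitrogen has a readable effect. The 2-hydroxyethyl and 3-hydroxypropyl chains cannot be told apart (a 1.6-fold higher number from compound 2 to compound 4 (0.19 log units; within the scatter)), so this pair shows no effect of chain length. The 4-hydroxycyclohexyl group of compound 1 still stands above compound 4 (a 3.9-fold lower number from compound 1 to compound 4 (0.59 log units; beyond the scatter)), and since compound 1 and compound 3 both carry a ring yet lie at opposite ends of the series, a ring alone does not set the half-life.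

On these data alone, it remains open whether an amine or a carboxylic acid at the chain end, or a methoxy group in place of the hydroxyl, would match these numbers, and nothing available explains the differences seen here.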